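Chloroethyl for acetoxyethyl on two pyrimidine cores

The source may hold more compounds than are shown below. What is called first, only, known or untested is meant among the compounds shown, and "the series" means these compounds.

The series pairs two cores with two side chains. Compound 1 `CC(=O)OCCc1c(C)[nH]c(=O)[nH]c1=O` carries the acetoxyethyl chain on the dioxo core. In a functional assay on HCT-116 cells (Homo sapiens) for antiproliferative activity, read by MTT assay, with a stated time of 24 h (on this read-out higher numbers stand for weaker inhibition and lower numbers for stronger inhibition), compound 1 gives > 100000 nM, which is a limit of the assay and not a number. Compound 2 `CC(=O)OCCc1c(C)nc(Cl)nc1Cl` carries the same chain on the dichloro core; in this assay compound 2 gives > 100000 nM, again a limit of the assay rather than a number. How the two cores differ is not broken down here. Compound 3 `Cc1nc(Cl)nc(Cl)c1CCCl` is the chloroethyl counterpart of compound 2. In this assay compound 3 gives 2000 nM. The change chloro in place of acetoxy on a saturated chain carbon, two bonds along the chain from an aromatic carbon therefore produced an at least 50-fold lower number from compound 2 to compound 3 (1.69 log units; beyond the scatter), a step that is itself bounded by a limit, since one end rests on (the limit of > 100000 nM in this assay, at which 2 of the 3 values shown sit).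

For the measured compounds named here, compound 4 `Cc1[nH]c(=O)[nH]c(=O)c1CCCl` is the unmeasured chloroethyl counterpart of compound 1; the change chloro in place of acetoxy on a saturated chain carbon, two bonds along the chain from an aromatic carbon is the same as the one from compound 2 to compound 3, at the same place. Whether it moves compound 4 as far as compound 3 cannot be read from two cores with no broken-down difference between them, and the starting point of compound 1 is only a limit. The expectation for compound 4 is a step of an at least 3.3-fold lower number from compound 1 to compound 4 (0.52 log units; beyond the scatter) in this assay, weaker than the measured one and with a real chance of another limit. Compound 4 is thus estimated at 30000 nM, between 3000 nM and 200000 nM.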

Compound 4, half-maximal inhibitory concentration: > 100000 nM
Compound 4: a limit, no number (the forecaster's own chance of this, stated with the estimate: 45%); middle value at least 3.3-fold (0.52 log units) away from the limit.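

In this assay compound 4 gives > 100000 nM, a limit of the assay and not a number. Compound 1 also stands at a limit, so no step between compound 1 and compound 4 can be read, because both ends rest on it: the limit of > 100000 nM in this assay, at which 3 of the 4 values shown sit.

The compounds shown leave open whether chloro in place of acetoxy changes anything on the core of compound 1.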